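Swapping Methyl for Nitro on the Sulfonyl Ring

The source may report more compounds than this note shows. Statements on the series, on what has been measured and on what is new or still open speak of the compounds shown alone.

Compound 1 `Cc1ccc(S(=O)(=O)N2C/C(=C\c3cccnc3)C(=O)/C(=C/c3ccccc3C(F)(F)F)C2)cc1` and compound 2 `O=C1/C(=C/c2cccnc2)CN(S(=O)(=O)c2ccc([N+](=O)[O-])cc2)C/C1=C\c1ccccc1C(F)(F)F` share one core, while compound 3 `Cc1ccc(S(=O)(=O)N2C/C(=C\c3ccncc3)C(=O)/C(=C/c3ccccc3C(F)(F)F)C2)cc1` and compound 4 `O=C1/C(=C/c2ccncc2)CN(S(=O)(=O)c2ccc([N+](=O)[O-])cc2)C/C1=C\c1ccccc1C(F)(F)F` share another. The two cores differ by pyridin-4-yl in place of pyridin-3-yl on a double-bonded chain carbon bound to a double-bonded ring carbon. In a functional assay on QGY-7703 cells (Homo sapiens) for cytotoxicity, read by MTT assay, with a stated time of 24 h (a lower number here means a stronger inhibitor, a higher number a weaker inhibitor), compound 1 gives 6170 nM, and compound 3 gives 5090 nM; the step between them is a 1.2-fold lower number from compound 1 to compound 3 (0.08 log units; within the scatter). Compound 2 carries nitro in place of methyl on an aromatic carbon, and in this assay compound 2 gives 7660 nM, so that a 1.2-fold higher number from compound 1 to compound 2 (0.09 log units; within the scatter). The change from compound 3 to compound 4 is the same one: nitro in place of methyl on an aromatic carbon. Going by the values given here, only one measured pair shows this change, and its step lies within the scatter, so the expectation for compound 4 rests on a single comparison. Resting on a 1.2-fold higher number from compound 1 to compound 2 (0.09 log units; within the scatter), the expected step for compound 4 is a 1.2-fold higher number from compound 3 to compound 4 (0.08 log units; within the scatter). Compound 4 is therefore estimated to give about 6100 nM in this assay, with a likely range from 3000 nM to 12500 nM.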

Compound 4, half-maximal inhibitory concentration: 9730 nM
For compound 4 the middle estimate is 1.6-fold (0.20 log units) below the measured one; low and high end bracket the measured number.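

In this assay, nitro in place of methyl gives a 1.9-fold higher number from compound 3 to compound 4 (0.28 log units; within the scatter), and pyridin-4-yl in place of pyridin-3-yl gives a 1.3-fold higher number from compound 2 to compound 4 (0.10 log units; within the scatter); neither step stands out from the usual scatter, so neither can be read as a real effect of the change. The nitro change shows no detectable dependence on the core, although with steps this small, that agreement shows only that little can be seen on either core, not that a larger effect would carry across: the same change on two cores in this assay, a 1.2-fold higher number (0.09 log units; within the scatter) from compound 1 to compound 2 and a 1.9-fold higher number (0.28 log units; within the scatter) from compound 3 to compound 4, 1.5-fold (0.19 log units) apart, within the scatter of two such steps The pyridine change gives the same picture, and these four compounds alone cannot establish a rule for the wider series: the same change on two cores in this assay, a 1.2-fold lower number (0.08 log units; within the scatter) from compound 1 to compound 3 and a 1.3-fold higher number (0.10 log units; within the scatter) from compound 2 to compound 4, 1.5-fold (0.19 log units) apart, within the scatter of two such steps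

Still open, from the compounds shown here alone, is whether an amine or a carboxylic acid in place of methyl or nitro on that ring would give a step beyond the scatter. Also open, going by these compounds, is whether a plain phenyl in place of the pyridine ring would do so, and whether any such step would carry from one core to another.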